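A few compounds are considered here, and "the series" means these few. Any claim that something is new, unique, unknown or untested is made for them only; others in the source may bear on it.

Measured compounds:
Compound 1, `CCCN1CC[C@@]2(OC)OC(N)=C(C#N)[C@@H](c3ccc(Br)cc3)[C@@H]2C1`: 19400 nM
Compound 2, `CO[C@@]12CCN(C)C[C@H]1[C@H](c1ccc(F)cc1)C(C#N)=C(N)O2`: 19400 nM

As far as these compounds go, the study covers two measured compounds and one still open. Compound 1, `CCCN1CC[C@@]2(OC)OC(N)=C(C#N)[C@@H](c3ccc(Br)cc3)[C@@H]2C1`, and compound 2, `CO[C@@]12CCN(C)C[C@H]1[C@H](c1ccc(F)cc1)C(C#N)=C(N)O2`, share a core and differ in the group on the ring nitrogen and in the halogen on the aryl ring. In a functional assay on trachea (Cavia porcellus) (a lower number here means a stronger inhibitor, a higher number a weaker inhibitor), compound 1 gives 19400 nM, and in this assay compound 2 gives 19400 nM. The two values are level at the digits shown, so compound 2 stands within the scatter of compound 1 and no difference between them can be read.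

Compound 3, `CCCN1CC[C@@]2(OC)OC(N)=C(C#N)[C@@H](c3ccc(F)cc3)[C@@H]2C1`, is the next step from compound 2: ethyl in place of hydrogen on a saturated chain carbon bound to an amine nitrogen in a ring. It thus carries the same chain on the nitrogen as compound 1 together with the fluorine of compound 2. For the measured compounds named here, no step between measured compounds is available to size this change, but since compound 1 gives 19400 nM with the longer chain and compound 2 gives 19400 nM with the shorter one, no shift beyond the scatter is expected in this assay. The step from compound 2 to compound 3 is estimated at a 1.0-fold lower number from compound 2 to compound 3 (0.01 log units; within the scatter). Compound 3 is expected to give 19000 nM, in the range 6000 nM to 60000 nM.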

Compound 3, half-maximal inhibitory concentration: 29600 nM
Compound 3: the middle estimate sits 1.6-fold (0.19 log units) below what was measured, and the stated range covers the measured number.
By their numbers in this assay, from the lowest: compounds 1, 2 and 3 (each within the scatter of the next).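

Compounds 1 and 2 differ in two places at once, so their level values could not size either change alone; compound 3 separates them. In this assay, methyl to propyl with the fluorine held fixed, which is ethyl in place of hydrogen on a saturated chain carbon bound to an amine nitrogen in a ring, reads as a 1.5-fold higher number from compound 2 to compound 3 (0.18 log units; within the scatter), while fluoro in place of bromo on an aromatic carbon with the propyl chain held fixed reads as a 1.5-fold higher number from compound 1 to compound 3 (0.18 log units; within the scatter), so neither single change moves the number beyond the scatter and the level values of compounds 1 and 2 do not rest on two large steps that cancel. Nothing available explains why these changes leave the number within the scatter.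

The three compounds cover only methyl and propyl in the one place and only fluoro and bromo in the other, so they do not tell whether a butyl chain or a benzyl group in the first place, or a methoxy group or a carboxylic acid in the second, would shift the number. They also leave open whether any change to the shared core would move the number beyond the scatter in this assay.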